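The compounds below may be only part of what the source reports. "The series", "measured", "known", "first", "only" and "open" are said of these compounds alone.

Compound 1 `CCC(CC)Nc1ncnc2c1ncn2C1O[C@H](CO)[C@@H](O)[C@H]1O`: 0.75 nM
Compound 2 `CCCn1c(=O)c2nc([C@H]3CC4C=CC3C4)[nH]c2n(CCC)c1=O`: 3.4 nM
Compound 3 `CC1(Nc2ncnc3c2ncn3C2O[C@H](CO)[C@@H](O)[C@H]2O)CCCCC1`: 70 nM

In an assay on cell membranes for binding affinity to adenosine receptor A1 (Cavia porcellus), read by radioligand binding (a lower number here means a stronger inhibitor, a higher number a weaker inhibitor), compound 2 gives the second highest of the three numbers: compound 1 sits lower at 0.75 nM and compound 3 higher at 70 nM. Compound 4 `CCCn1c(=O)c2nc(-c3ccco3)[nH]c2n(CCC)c1=O` has not yet been measured. It differs from compound 2 in one place: a group of 5 heavy atoms (4 carbon, 1 oxygen; one five-membered aromatic ring with 1 hetero atom) in place of a group of 7 heavy atoms (7 carbon; 2 five-membered non-aromatic rings of carbon only), on an aromatic carbon. Within the data shown here, the only measured step, a 93-fold higher number from compound 1 to compound 3 (1.97 log units; beyond the scatter), was large, but it concerns a group on a nitrogen of a different core, so it does not speak directly to a change on an aromatic carbon of the core of compound 2. Among the measured compounds shown here, with no directly comparable step, the expectation is a moderate rise in the number, beyond the scatter. Compound 4 is therefore estimated at 30 nM, with a range from 8 nM to 120 nM. This estimate corresponds to an expected step of an 8.8-fold higher number from compound 2 to compound 4 (0.95 log units; beyond the scatter).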

Compound 4, inhibition constant: 560 nM
Beside the measured number, compound 4's estimate is 19-fold (1.27 log units) below it; measured number outside the range, above it.
By their numbers in this assay, from the lowest: compound 1; then compound 2; then compound 3; then compound 4.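

In this assay, furan-2-yl in place of the group with two five-membered non-aromatic rings of carbon only gives a 160-fold higher number from compound 2 to compound 4 (2.22 log units; beyond the scatter). Among these compounds, this shows that the aromatic carbon between two ring nitrogen atoms is highly sensitive to what it carries, something the earlier compounds could not show. Nothing measured here accounts for the size of this step.

Among the compounds shown here, the single step changes ring type, heavy-atom count and oxygen content together, so their separate contributions remain open. Also open, going by these compounds, is how cyclopentyl, phenyl or thiophen-2-yl would fare at this carbon.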